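The source may hold more compounds than are shown below. What is called first, only, known or untested is meant among the compounds shown, and "the series" means these compounds.

Measured in a functional assay on J82 cells (Homo sapiens) for cytotoxicity, read by colorimetric assay and MTT assay; a higher number here means a weaker inhibitor, a lower number a stronger inhibitor:

- Compound 1 `COc1ccc(-c2cc3c(OC)ccc(OC)c3nc2O)cc1`: 10000 nM
- Compound 2 `CCOC(=O)Cn1c(=O)c(-c2ccc(OC)cc2)cc2c(OC)cc(OC)cc21`: 10000 nM

Only these two compounds have been measured so far, and their readings match. Compound 2 therefore stands level with compound 1 at 10000 nM, with no difference beyond the scatter of repeated measurements.

Compound 3 `CCN(CC)C(=O)CCn1c(=O)c(-c2ccc(OC)cc2)cc2c(OC)cc(OC)cc21` has not yet been measured. It differs from compound 2 in a single place: (diethylcarbamoyl)methyl in place of ethoxycarbonyl on a saturated chain carbon bound to an aromatic nitrogen. In other words, (diethylcarbamoyl)methyl takes the place of ethoxycarbonyl on a saturated chain carbon bound to an aromatic nitrogen.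

Among the measured compounds shown here, no measured pair shows this change on its own, so the forecast rests mainly on compound 2 at 10000 nM. The estimated step of a 1.3-fold lower number from compound 2 to compound 3 (0.10 log units; within the scatter) is expected to be slight, towards a stronger inhibitor, and to stay within the scatter. Compound 3 is expected at 8000 nM, with an estimated range of 2500 nM to 15000 nM.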

Compound 3, half-maximal inhibitory concentration: 10000 nM
Beside the measured number, compound 3's estimate is 1.3-fold (0.10 log units) below it, and the stated range covers the measured number.
By their numbers in this assay, from the lowest: compounds 1, 2 and 3 (each within the scatter of the next).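

In this assay, replacing ethoxycarbonyl with (diethylcarbamoyl)methyl on a saturated chain carbon bound to an aromatic nitrogen gives this step: no change at the digits printed from compound 2 to compound 3 (within the scatter). Among the compounds shown here, this is the first single change that can be read at this place, and it shows that going from 5 to 8 heavy atoms, with a nitrogen entering the group, leaves the reading in this assay unmoved. Nothing measured here offers an explanation for this result.

The compounds shown do not reveal whether any group at this place can lower the number, since a carboxylic acid or an amine at the end of the chain has no reading here. They also leave open whether 2-(diethylcarbamoyl)ethyl behaves the same way with a shorter or longer chain.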